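Swapping a Nitro Group for a Sulfonamide Tail

The source may hold more compounds than are shown below. What is called first, only, known or untested is meant among the compounds shown, and "the series" means these compounds.

Measured compounds:
- Compound 1, `Nc1ccc(CNC(=O)CC2c3ccccc3N=C(N3CCCCC3)N2c2ccccc2)cc1`: 13000 nM
- Compound 2, `CN(C)C1=Nc2ccccc2C(CC(=O)NCc2ccc(NS(=O)(=O)c3ccc(F)cc3)cc2)N1c1ccccc1`: 430 nM
- Compound 3, `CCN1C(N(C)C)=Nc2ccccc2C1CC(=O)NCc1ccc([N+](=O)[O-])cc1`: 2170 nM

These three compounds share a core and differ in the tail on the benzylic amide and in the groups on the core. In an assay on HEK293 cells for inhibition of Voltage-dependent T-type calcium channel subunit alpha-1G (Homo sapiens) (on this read-out lower numbers stand for stronger inhibition and higher numbers for weaker inhibition), compound 3 gives 2170 nM, the second highest of the three numbers. Compound 2 gives 430 nM, a lower number that lies beyond the scatter of repeated measurement. Compound 1 gives 13000 nM, a higher number, again beyond the scatter.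

Compound 4, `CCN1C(N(C)C)=Nc2ccccc2C1CC(=O)NCc1ccc(NS(=O)(=O)c2ccc(C)cc2)cc1`, has not yet been measured. Its difference from compound 3 is ((4-methylphenyl)sulfonyl)amino in place of nitro on an aromatic carbon. Compound 2 carries a related sulfonamide tail and shows a lower number than compound 3, but the two also differ elsewhere on the core, so no single step can be read off.

For compound 4 the expectation is a lower number than compound 3 in this assay, a step of a 2.4-fold lower number from compound 3 to compound 4 (0.38 log units; beyond the scatter), beyond the scatter. Compound 4 is estimated at 900 nM, within a range from 300 nM to 3000 nM.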

Compound 4, half-maximal inhibitory concentration: 1120 nM
Compound 4: the middle estimate sits 1.2-fold (0.09 log units) below what was measured, and the stated range covers the measured number.
By their numbers in this assay, from the lowest: compound 2; then compounds 4 and 3 (each within the scatter of the next); then compound 1.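

Within the data shown here, replacing nitro with ((4-methylphenyl)sulfonyl)amino on the aromatic carbon gives the first comparison here that differs in only one place: in this assay, the step is a 1.9-fold lower number from compound 3 to compound 4 (0.29 log units; within the scatter). The incoming group is much bigger and brings an aromatic ring and a hydrogen-bond donor, yet the two numbers cannot be told apart, so this position accepts the change without a measurable shift in this assay. No separate measurement bears on why the two compounds read alike.

Among these compounds, compounds 1 and 2 each differ from these two in more than one place, so no step to them can be read. Going by these compounds, it remains open how this position would respond to a smaller methylsulfonylamino group or a carboxylic acid, and whether any group here can move the number beyond the scatter.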